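Swapping the aryl on the amine: dichlorophenyl enters

This account rests on a few compounds, and the source may have more. Where it says the series, first, only, none or still open, it means among the compounds named here.

Compounds measured so far in a functional assay on MV4-11 cells (Homo sapiens) for inhibition, with a stated time of 120 h, tested at 10 uM; a higher number here means more inhibition at the concentration tested (going by the name of the read-out), a lower number less inhibition:
compound 1 `Cc1n[nH]c2ccc(-c3nc4cnc(N5CCN(C)CC5)cn4c3Nc3ccccc3F)cc12` gives 0%
compound 2 `Cc1n[nH]c2ccc(-c3nc4cnc(N5CCN(C)CC5)cn4c3Nc3ccc(Br)cc3Cl)cc12` gives 70.5%
compound 3 `COc1ccc(Nc2c(-c3ccc4[nH]nc(C)c4c3)nc3cnc(N4CCN(C)CC4)cn23)cc1OC` gives 6.27%

Compound 3 stands second highest of the three, near compound 1 and far below compound 2. The step to compound 4 `Cc1n[nH]c2ccc(-c3nc4cnc(N5CCN(C)CC5)cn4c3Nc3cc(Cl)ccc3Cl)cc12` is 2,5-dichlorophenyl in place of 3,4-dimethoxyphenyl on a nitrogen on an aromatic ring. Among the compounds with values here, the steps that bear on it are a number 64.2 percentage points lower from compound 2 to compound 3 (beyond the scatter) and a number 70.5 percentage points higher from compound 1 to compound 2 (beyond the scatter), both large, both showing a dihalogenated aryl far above the other aryls, while a number 6.3 percentage points higher from compound 1 to compound 3 (within the scatter) lies within the scatter. A large rise is therefore expected for compound 4, roughly reversing the drop from compound 2, though the new chlorine pattern differs from that of compound 2. Compound 4 is estimated at 50%, ranging from 15% to 80%, a step of a number 43.7 percentage points higher from compound 3 to compound 4 (beyond the scatter).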

Compound 4, a percentage reported as inhibition, at one concentration (the size of the read-out at that concentration, not a potency): 23.8%
The estimate for compound 4 lay 26.2 percentage points above the measured number, and the stated range covers the measured number.
By their numbers in this assay, from the lowest: compounds 1 and 3 (each within the scatter of the next); then compound 4; then compound 2.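

In this assay, the 2,5-dichlorophenyl group falls short of the 4-bromo-2-chlorophenyl group, with a number 46.7 percentage points lower from compound 2 to compound 4 (beyond the scatter) at the same nitrogen, so two halogens on this aryl do not by themselves reach the level of compound 2. It still stands clear of the other two aryls, with a number 17.5 percentage points higher from compound 3 to compound 4 (beyond the scatter) and a number 23.8 percentage points higher from compound 1 to compound 4 (beyond the scatter) placing compound 4 at an intermediate level. Nothing available explains these differences. Open, on these data alone, is whether bromine itself or the placement of the halogens separates compound 2 from compound 4, and what an aryl bearing a nitrile or an amine would give.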